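Trading a fluoro for trifluoromethoxy on the urea aryl ring

The source may hold more compounds than are shown below. What is called first, only, known or untested is meant among the compounds shown, and "the series" means these compounds.

Two ureas sharing one core have been measured. Compound 1 `CC(C)c1cccc(NC(=O)Nc2ccc(Oc3ncnc4[nH]ncc34)cc2)c1` carries an isopropyl group; in an assay on isolated protein for inhibition of vascular endothelial growth factor receptor 2 (Danio rerio), read by fluorescence and microscopy, with a stated time of 33 h (on this read-out higher numbers stand for weaker inhibition and lower numbers for stronger inhibition), compound 1 gives 7730 nM. Compound 2 `O=C(Nc1ccc(Oc2ncnc3[nH]ncc23)cc1)Nc1cccc(F)c1` carries a fluoro instead; in this assay compound 2 gives 16600 nM, the highest of the two numbers, and the step of a 2.1-fold higher number from compound 1 to compound 2 (0.33 log units; beyond the scatter) is modest but beyond the scatter. Compound 3 `O=C(Nc1ccc(Oc2ncnc3[nH]ncc23)cc1)Nc1cccc(OC(F)(F)F)c1` is not yet measured. It differs from compound 2 in one place: trifluoromethoxy in place of fluoro on an aromatic carbon, on an aromatic carbon of a six-membered aromatic ring of carbon only, meta to a large group. Within the data shown here, the only step that bears on this is the one from compound 1 to compound 2, where a fluoro replaced a larger group and the number rose. Compound 3 is therefore expected to move back toward a lower number, by a 1.8-fold lower number from compound 2 to compound 3 (0.27 log units; within the scatter) in this assay. Compound 3 is estimated at 9000 nM, within 4000 nM to 20000 nM.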

Compound 3, half-maximal inhibitory concentration: 17800 nM
Beside the measured number, compound 3's estimate is 2.0-fold (0.30 log units) below it, within the range that was stated.
By their numbers in this assay, from the lowest: compound 1; then compounds 2 and 3 (each within the scatter of the next).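

In this assay, trifluoromethoxy in place of fluoro gives a 1.1-fold higher number from compound 2 to compound 3 (0.03 log units; within the scatter) and so leaves the two numbers indistinguishable, even though the entering group has 5 heavy atoms and the leaving group has 1. Heavy-atom count alone therefore does not track the number at this position, and isopropyl remains apart from trifluoromethoxy, with a 2.3-fold higher number from compound 1 to compound 3 (0.36 log units; beyond the scatter) and a size of step that is only modest. No measurement shown here offers an explanation for this pattern among the three compounds.

The compounds shown leave open whether the lower number belongs to isopropyl alone or would also appear with a related carbon group such as tert-butyl or cyclopropyl. They also leave open how an amine or a carboxylic acid would behave on this aromatic carbon.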